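The source may hold more compounds than are shown below. What is called first, only, known or untested is meant among the compounds shown, and "the series" means these compounds.

Compound 1 `O=C(Nc1cccc(-n2cc(-c3ccncc3)c(-c3cc(O)cc(Cl)c3)n2)c1)Nc1ccc(Cl)c(C(F)(F)F)c1`: 9.31%
Compound 2 `O=C(Nc1cccc(-n2cc(-c3ccncc3)c(-c3cc(O)cc(Cl)c3)n2)c1)Nc1ccc(Cl)c(Cl)c1`: 4.11%
Compound 3 `COc1cc(Cl)cc(-c2nn(-c3cccc(NC(=O)Nc4ccc(Cl)c(C(F)(F)F)c4)c3)cc2-c2ccncc2)c1`: 1.88%

In a functional assay on CCRF-CEM cells (Homo sapiens) for inhibition, read by sulforhodamine B assay, with a stated time of 48 h, tested at 10 uM (on this read-out lower numbers stand for a stronger effect and higher numbers for a weaker effect at the one concentration tested), compound 1 gives 9.31%, compound 2 gives 4.11% and compound 3 gives 1.88%. Compound 2 differs from compound 1 by chloro in place of trifluoromethyl on an aromatic carbon, a change that made a number 5.2 percentage points lower from compound 1 to compound 2 (within the scatter). Compound 3 differs from compound 1 by methyl in place of hydrogen on an oxygen on an aromatic ring, a step of a number 7.4 percentage points lower from compound 1 to compound 3 (within the scatter). Compound 4 `COc1cc(Cl)cc(-c2nn(-c3cccc(NC(=O)Nc4ccc(Cl)c(Cl)c4)c3)cc2-c2ccncc2)c1` has not yet been measured in this assay. It differs from compound 3 by chloro in place of trifluoromethyl on an aromatic carbon, the same change as the one already seen, with the same surroundings. Because compound 3 already gives 1.88%, a value near the bottom of the scale, the step is expected to be small, about a number 0.4 percentage points lower from compound 3 to compound 4 (within the scatter). Compound 4 is therefore estimated at 1.5%, between 0% and 8%.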

Compound 4, a percentage reported as activity, at one concentration (the size of the read-out at that concentration, not a potency): 5.73%
Compound 4: the middle estimate sits 4.2 percentage points below what was measured; the measured number falls inside the stated range.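

In this assay, chloro in place of trifluoromethyl gives a number 3.9 percentage points higher from compound 3 to compound 4 (within the scatter), and this step does not differ meaningfully from the earlier one on the other core: the same change on two cores in this assay, a number 5.2 percentage points lower (within the scatter) from compound 1 to compound 2 and a number 3.9 percentage points higher (within the scatter) from compound 3 to compound 4, 9.1 percentage points apart, within the scatter of two such steps. Methyl in place of hydrogen on the oxygen gives a number 1.6 percentage points higher from compound 2 to compound 4 (within the scatter), which also agrees with its earlier step: the same change on two cores in this assay, a number 7.4 percentage points lower (within the scatter) from compound 1 to compound 3 and a number 1.6 percentage points higher (within the scatter) from compound 2 to compound 4, 9.1 percentage points apart, within the scatter of two such steps. Both changes therefore carry from one core to the other without a detectable difference, but each step lies within the scatter, so this shows neither a real effect of either change nor a true reversal where the steps point in opposite directions.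

The compounds shown leave open whether a nitrile or an amine in place of trifluoromethyl would shift the number beyond the scatter. They also leave open what a carboxylic acid in place of the oxygen-bearing group would do.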